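Silicon aryl variation in the squalene monooxygenase series

The source may hold more compounds than are shown below. What is called first, only, known or untested is meant among the compounds shown, and "the series" means these compounds.

Two compounds of the series have numbers in a functional assay on liver (Sus scrofa) for inhibition of squalene monooxygenase (Homo sapiens), using microsomes; on this read-out lower numbers stand for stronger inhibition and higher numbers for weaker inhibition. Compound 1 `CCN(C/C=C/C#CC(C)(C)C)Cc1cccc(OC[Si](C)(C)c2ccc(Br)cc2)c1` gives 210 nM in this assay, and compound 2 `CCN(C/C=C/C#CC(C)(C)C)Cc1cccc(OC[Si](C)(C)c2ccccc2C)c1` gives 30 nM. Among the measured compounds shown here, the single step between them, a 7.0-fold lower number from compound 1 to compound 2 (0.85 log units; beyond the scatter), leaves compound 2 with the lowest of the two numbers, compound 1 standing a clear distance above it. Compound 3 `CCN(C/C=C/C#CC(C)(C)C)Cc1cccc(OC[Si](C)(C)c2ccc(C=O)cc2)c1` is the next member, differing from compound 2 in one place: 4-formylphenyl in place of 2-methylphenyl on a silicon. For the measured compounds named here, only the step from compound 1 to compound 2 bears on this change, and it was modest in size. Compound 3 returns to a phenyl bearing a group in the same 4-position as the 4-bromophenyl of compound 1, so a move back toward the number of compound 1 is expected, though the formyl group is without precedent here. The expected step is a 4.0-fold higher number from compound 2 to compound 3 (0.60 log units; beyond the scatter). For compound 3 the estimate in this assay is 120 nM, within a range from 40 nM to 400 nM.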

Compound 3, half-maximal inhibitory concentration: 100 nM
Compound 3: middle estimate off by 1.2-fold (0.08 log units), on the high side; low and high end bracket the measured number.
By their numbers in this assay, from the lowest: compound 2; then compound 3; then compound 1.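

In this assay the aryl group on silicon now shows a difference between two groups at the same ring position: formyl in place of bromo gives a 2.1-fold lower number from compound 1 to compound 3 (0.32 log units; beyond the scatter) and so lowers the number, though not to the level of compound 2. The change from 2-methylphenyl to 4-formylphenyl gives a 3.3-fold higher number from compound 2 to compound 3 (0.52 log units; beyond the scatter) and leaves compound 2 with the lowest number of the three. No measurement accounts for either step, so the order stays descriptive here.

From the compounds shown here alone, how an unsubstituted phenyl or a 4-methylphenyl on the silicon would stand remains open, so the effect of the methyl group cannot yet be separated from that of its place on the ring. Also open, going by these compounds, is whether a 4-carboxylic acid, a 4-amine or a 4-methoxy group would follow the formyl or the bromo compound.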